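The source may report more compounds than this note shows. Statements on the series, on what has been measured and on what is new or still open speak of the compounds shown alone.

Working notes on the series, a functional assay on OVCAR-5 cells (Homo sapiens) for inhibition, read by sulforhodamine B assay, with a stated time of 48 h, tested at 10 uM; on this read-out lower numbers stand for less inhibition and higher numbers for more inhibition at the one concentration tested (going by the name of the read-out).

Three compounds carry numbers. Compound 1 `Fc1ccc(-c2cn3ccnc3c(-c3ccc4ncn(C5CCCCC5)c4c3)n2)cc1` gives 10.3% in this assay, compound 2 `Clc1ccc(-c2cn3ccnc3c(-c3ccc4ncn(C5CCCCC5)c4c3)n2)cc1` gives 0.84%, and compound 3 `COc1ccccc1-c1cn2ccnc2c(-c2ccc3ncn(C4CCCCC4)c3c2)n1` gives 6.61%. The three differ only in the aryl group on the shared core, and every step among them stays inside the scatter: a number 9.5 percentage points lower from compound 1 to compound 2 (within the scatter), a number 3.7 percentage points lower from compound 1 to compound 3 (within the scatter), a number 5.8 percentage points higher from compound 2 to compound 3 (within the scatter). Compound 3 thus stands second highest of the three numbers, with compound 1 nearest and compound 2 furthest, but no ordering among them can be claimed.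

Compound 4 `Fc1ccccc1-c1cn2ccnc2c(-c2ccc3ncn(C4CCCCC4)c3c2)n1` is not yet measured. Relative to compound 3 the change is fluoro in place of methoxy on an aromatic carbon. Within the data shown here, no measured step swaps methoxy for fluoro at this place; the steps from compound 1 to compound 3 and from compound 2 to compound 3 exchange the whole aryl group, and both sit within the scatter. On that basis no step beyond the scatter is expected for compound 4, a number 0.6 percentage points lower from compound 3 to compound 4 (within the scatter). Compound 4 is estimated at 6%, with a range of 0% to 18%.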

Compound 4, a percentage reported as inhibition, at one concentration (the size of the read-out at that concentration, not a potency): 6.64%
The estimate for compound 4 lay 0.6 percentage points below the measured number; measured number inside the range.
By their numbers in this assay, from the lowest: compounds 2, 3, 4 and 1 (each within the scatter of the next).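

In this assay the exchange of methoxy for fluoro on an aromatic carbon ortho to a large group reads a number 0 percentage points higher from compound 3 to compound 4 (within the scatter) and is the only step shown that swaps one group for another at this place. Among these compounds, the step of a number 3.7 percentage points lower from compound 1 to compound 4 (within the scatter) is the only comparison of 2-fluorophenyl with 4-fluorophenyl, so for fluoro the two placings on the ring cannot be told apart in this assay. The step of a number 5.8 percentage points higher from compound 2 to compound 4 (within the scatter) likewise leaves 2-fluorophenyl and 4-chlorophenyl unseparated, and no measurement on hand accounts for any of these numbers.

Every step shown stays inside the scatter, so this place has not yet shown any effect on the read-out. On these data alone, whether an amine, a carboxylic acid or a longer alkoxy chain here would give a step beyond the scatter remains open.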